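Furan-2-yl for cyclopropyl on two related cores

The compounds below may be only part of what the source reports. "The series", "measured", "known", "first", "only" and "open" are said of these compounds alone.

Measured compounds:
compound 1 `c1ccc(C(/N=C2\CCCCN2)C2CC2)cc1`: 33%
compound 2 `c1ccc(C(/N=C2\CCCCCN2)C2CC2)cc1`: 41%
compound 3 `c1ccc(C(/N=C2\CCCCN2)c2ccco2)cc1`: 28%

Of the compounds shown here, three have been tested in a functional assay on the whole organism (plasma, strain Sprague-Dawley) with Rattus norvegicus as the target, with a stated time of 2 h, at a dose of 50 mg/kg by the oral route; a lower number here means a weaker effect, a higher number a stronger effect of the compound at the dose given. Compound 1 gives 33%, compound 2 gives 41%, and compound 3 gives 28%. Compound 2 stands highest of the three, but its gap to compound 1 lies within the scatter, so the two are not ranked against each other; only its gap to compound 3 lies beyond the scatter.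

Compound 1 and compound 3 differ in one place: furan-2-yl in place of cyclopropyl on a saturated chain carbon bound to an aromatic carbon and a double-bonded nitrogen. This change made a step of a number 5 percentage points lower from compound 1 to compound 3 (within the scatter). The difference between the core of compound 1 and the core of compound 2 is not broken down here.

Compound 4 `c1ccc(C(/N=C2\CCCCCN2)c2ccco2)cc1` is not yet measured in this assay. It differs from compound 2 in the same kind of way: furan-2-yl in place of cyclopropyl on a saturated chain carbon bound to an aromatic carbon and a double-bonded nitrogen. The place of the change is described in the same words for both pairs, so the same kind of change is being made on the other core.

Going by the values given here, for compound 4 a small step is expected, because a number 5 percentage points lower from compound 1 to compound 3 (within the scatter) is the only record of this change and it lies within the scatter. The estimated step is a number 5 percentage points lower from compound 2 to compound 4 (within the scatter). Compound 4 is therefore expected to give about 36%, with a range from 22% to 50%. This rests on one pair of compounds only, and the scatter of this assay is wide relative to the step seen.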

Compound 4, a percentage reported as inhibition, in the whole organism at one dose (the size of the read-out at that dose, not a potency): 37%
For compound 4 the middle estimate is 1 percentage points below the measured one; low and high end bracket the measured number.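

In this assay, furan-2-yl in place of cyclopropyl gives a number 4 percentage points lower from compound 2 to compound 4 (within the scatter), and the steps for this change on the two cores agree: the same change on two cores in this assay, a number 5 percentage points lower (within the scatter) from compound 1 to compound 3 and a number 4 percentage points lower (within the scatter) from compound 2 to compound 4, 1 percentage points apart, within the scatter of two such steps So, in the two pairs shown, the change can be carried from the core of compound 1 to the core of compound 2 with the same outcome, a step too small to separate from the ordinary spread of repeated measurements. This does not show that the swap has a real effect on either core, nor that the agreement would hold on any other core, as it rests on just two pairs, each read at a single dose and time, which gives the size of the effect at that dose rather than a potency.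

Both groups compared here are small rings, so the compounds shown leave open what a carboxylic acid, an amine or a longer alkyl chain would do on a saturated chain carbon bound to an aromatic carbon and a double-bonded nitrogen. They also leave open whether any such replacement would give a step beyond the scatter and, if so, whether that step would carry over between the two cores.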